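The source may hold more compounds than are shown below. What is called first, only, known or untested is meant among the compounds shown, and "the series" means these compounds.

In an assay on cell membranes for displacement of a labelled ligand from Translocator protein (Rattus norvegicus), read by scintillation counting, with a stated time of 90 min (a lower number here means a stronger inhibitor, a higher number a weaker inhibitor), compound 1 `CCC(CC)C(=O)Cc1c(-c2ccc(Cl)cc2)nn2c(C)cc(C)nc12` gives 2.4 nM, and compound 2 `CCC(CC)C(=O)Cc1c(-c2ccc(Cl)cc2)nn2c(-c3ccccc3)cc(C)nc12` gives 2.4 nM. Going by the values given here, the single measured step, no change at the digits printed from compound 1 to compound 2 (within the scatter), leaves the two level within the scatter. Compound 3 `CCC(CC)C(=O)Cc1c(-c2ccc(Cl)cc2)nn2c(C)cc(-c3ccccc3)nc12` differs from compound 1 by phenyl in place of methyl on an aromatic carbon, on the aromatic carbon next to the ring nitrogen, meta to a methyl group. Since the step from compound 1 to compound 2 put the same phenyl at a different aromatic carbon of the shared core without any change beyond the scatter, the step of no change at the digits printed from compound 1 to compound 3 (within the scatter) is expected to be small as well. Compound 3 is therefore estimated at 2.4 nM, within 1.2 nM to 5 nM.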

Compound 3, inhibition constant: 3.4 nM
For compound 3 the middle estimate is 1.4-fold (0.15 log units) below the measured one; the measured number falls inside the stated range.
By their numbers in this assay, from the lowest: compounds 1, 2 and 3 (each within the scatter of the next).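

In this assay, putting phenyl in place of methyl on the aromatic carbon next to the ring nitrogen gives a 1.4-fold higher number from compound 1 to compound 3 (0.15 log units; within the scatter). Going by these compounds alone, this shows that a second position on the shared core, not only the one changed in compound 2, can carry six heavy atoms and an added aromatic ring in place of a single methyl carbon with no change beyond the scatter.

As far as these compounds go, whether an amine, a carboxylic acid or a longer chain on this carbon would also leave the number within the scatter remains open. Nothing available explains why the swap makes so little difference.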